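The source may report more compounds than this note shows. Statements on the series, on what has been measured and on what is new or still open speak of the compounds shown alone.

Measured so far in a functional assay on K562 cells (Homo sapiens), read by MTT assay, with a stated time of 72 h; a lower number here means a stronger inhibitor, a higher number a weaker inhibitor:

compound 1 `Cc1ncnc2c1c(-c1cccs1)cn2[C@@H]1O[C@H](CO)[C@@H](O)[C@H]1O` — > 20000 nM
compound 2 `CNc1ncnc2c1c(-c1cccs1)cn2[C@@H]1O[C@H](CO)[C@@H](O)[C@H]1O` — > 20000 nM
compound 3 `CN(C)c1ncnc2c1c(-c1cccs1)cn2[C@@H]1O[C@H](CO)[C@@H](O)[C@H]1O` — > 20000 nM

In this assay compound 1 gives > 20000 nM, which is a limit of the assay and not a number. Compound 2 gives > 20000 nM, likewise a limit. Compound 3 gives > 20000 nM, again a limit. Compound 2 therefore stands at the limit together with the other two, and no order among the three can be read. The three steps, a step that the two limits leave unreadable from compound 1 to compound 2, a step that the two limits leave unreadable from compound 1 to compound 3 and a step that the two limits leave unreadable from compound 2 to compound 3, are all unreadable in size, because of the limit of > 20000 nM in this assay, at which 3 of the 3 values shown sit.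

Compound 4 `CNc1ncnc2c1c(-c1ccco1)cn2[C@@H]1O[C@H](CO)[C@@H](O)[C@H]1O` differs from compound 2 at a different place: furan-2-yl in place of thiophen-2-yl on an aromatic carbon. For the measured compounds named here, none of the measured steps touches this position, and all of them are themselves unreadable, so no measured step bears on the change in size or direction. Going by the values given here, the only grounding is that compound 2 sits at the limit, > 20000 nM. Compound 4 is expected to sit at the same limit, an expected step of a number no higher from compound 2 to compound 4 (the limit leaves the size open), and compound 4 is estimated at 20000 nM, within 5000 nM to 60000 nM.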

Compound 4, half-maximal inhibitory concentration: 15100 nM
Beside the measured number, compound 4's estimate is 1.3-fold (0.12 log units) above it; low and high end bracket the measured number.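

The change of thiophen-2-yl to furan-2-yl on this aromatic carbon gives the series its first readable step in this assay: an at least 1.3-fold lower number from compound 2 to compound 4 (0.12 log units; that floor lies within the scatter). This is also the first sign that this position, rather than the methyl, methylamino and dimethylamino positions, can bring a value inside the assay's range, though the floor of the step does not on its own separate the two groups. The full size of the step stays unreadable, as do the steps among the three earlier compounds, because each of those compounds stands at a limit: the limit of > 20000 nM in this assay, at which 3 of the 4 values shown sit.

Still open, as far as these compounds go, is how a phenyl ring or a longer chain would read on this aromatic carbon. Also open, from the compounds shown here alone, is whether methyl or dimethylamino in place of methylamino would shift the number when furan-2-yl is present.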